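Removing the Bromine From a Compound at the Assay Limit

The source may report more compounds than this note shows. Statements on the series, on what has been measured and on what is new or still open speak of the compounds shown alone.

In an ADME assay on NCI/ADR-RES cells (Homo sapiens) for inhibition, read by MTT assay, with a stated time of 48 h (on this read-out higher numbers stand for weaker inhibition and lower numbers for stronger inhibition), compound 2 `CC(=O)O[C@@H]1C[C@@H](OC(=O)c2ccccc2)/C(C)=C/[C@H]2[C@@H](OC(=O)c3ccccc3)[C@@H](C)[C@H](OC(=O)c3ccc(Br)cc3)[C@]2(OC(C)=O)[C@H](O)[C@](C)(O)/C=C/C1(C)C` gives > 150000 nM, which is a limit. Compound 1 `CC(=O)O[C@@H]1C[C@@H](OC(=O)c2ccccc2)/C(C)=C/[C@H]2[C@@H](OC(=O)c3ccccc3)[C@@H](C)[C@H](O)[C@]2(OC(C)=O)[C@H](O)[C@](C)(O)/C=C/C1(C)C` gives > 150000 nM, also a limit. Compound 3 `CC(=O)O[C@@H]1C[C@@H](OC(=O)c2ccccc2)/C(C)=C/[C@H]2[C@@H](OC(=O)c3ccccc3)[C@@H](C)[C@H](OC(=O)c3ccco3)[C@]2(OC(C)=O)[C@H](O)[C@](C)(O)/C=C/C1(C)C` gives > 150000 nM, again a limit. Every measurement so far thus rests on (the limit of > 150000 nM in this assay, at which 3 of the 3 values shown sit).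

Compound 4 `CC(=O)O[C@@H]1C[C@@H](OC(=O)c2ccccc2)/C(C)=C/[C@H]2[C@@H](OC(=O)c3ccccc3)[C@@H](C)[C@H](OC(=O)c3ccccc3)[C@]2(OC(C)=O)[C@H](O)[C@](C)(O)/C=C/C1(C)C` carries hydrogen in place of bromo on an aromatic carbon, turning 4-bromophenyl into phenyl: hydrogen in place of bromo on an aromatic carbon.

For the measured compounds named here, three measured steps bear on this change: a step that the two limits leave unreadable from compound 1 to compound 2, a step that the two limits leave unreadable from compound 1 to compound 3 and a step that the two limits leave unreadable from compound 2 to compound 3. On the strength of a step that the two limits leave unreadable from compound 2 to compound 3, no step beyond the scatter is expected in this assay, in either direction, and the expected change is a number no higher from compound 2 to compound 4 (the limit leaves the size open). Compound 4 is estimated at 150000 nM, with a range of 70000 nM to 300000 nM, and another limit is the likely report.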

Compound 4, half-maximal inhibitory concentration: 64200 nM
For compound 4 the middle estimate is 2.3-fold (0.37 log units) above the measured one; the measured number lies below the stated range.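

Compound 4 is the only compound shown to give a number inside the range of this assay, and this oxygen on the shared core now yields readable steps: an at least 2.3-fold lower number from compound 2 to compound 4 (0.36 log units; beyond the scatter), an at least 2.3-fold lower number from compound 1 to compound 4 (0.36 log units; beyond the scatter) and an at least 2.3-fold lower number from compound 3 to compound 4 (0.36 log units; beyond the scatter). Carrying an acyl group there does not suffice, since compound 2 and compound 3 both carry one and sit at the limit, whereas benzoyl in compound 4 does not. The steps among compound 1, compound 2 and compound 3 cannot be read: the limit of > 150000 nM in this assay, at which 3 of the 4 values shown sit.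

On these data alone, how far these three lie past the limit remains open, and with it the true size of each step. Also open, as far as these compounds go, is how an amine in place of the bromo, or a longer chain in place of benzoyl, would read.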